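Swapping the aryl group on a weak growth inhibitor

This account rests on a few compounds, and the source may have more. Where it says the series, first, only, none or still open, it means among the compounds named here.

Measured so far:
compound 1, `Cc1cc(F)ccc1Nc1ncc(C(F)(F)F)c(N2Cc3cccc(N(C)S(C)(=O)=O)c3C2)n1`: > 30000 nM
compound 2, `CN(c1cccc2c1CN(c1nc(Nc3ccc(Cl)c(C(F)(F)F)c3)ncc1C(F)(F)F)C2)S(C)(=O)=O`: 15200 nM

In a functional assay on A549 cells (Homo sapiens) for antiproliferative activity, read by spectrophotometry, with a stated time of 2 days (a higher number here means a weaker inhibitor of growth, a lower number a stronger inhibitor of growth), compound 1 gives > 30000 nM, which is a limit of the assay and not a number. Compound 2 gives 15200 nM in this assay. Compound 3, `CN(c1cccc2c1CN(c1nc(Nc3cccc(C(F)(F)F)c3)ncc1C(F)(F)F)C2)S(C)(=O)=O`, is not yet measured; it differs from compound 1 by 3-(trifluoromethyl)phenyl in place of 4-fluoro-2-methylphenyl on a nitrogen on an aromatic ring. Within the data shown here, the only measured step at this place is an at least 1.9-fold lower number from compound 1 to compound 2 (0.29 log units; that floor lies within the scatter), a floor only due to the limit of > 30000 nM in this assay, at which 1 of the 2 values shown sits. A similar change here is expected to move the number no further than that: the expected step is an at least 1.5-fold lower number from compound 1 to compound 3 (0.17 log units; that floor lies within the scatter), giving compound 3 an estimated 20000 nM, between 8000 nM and 60000 nM.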

Compound 3, concentration for 50% growth inhibition: > 30000 nM
Compound 3: a limit, no number (the forecaster's own chance of this, stated with the estimate: 40%); at least 1.5-fold (0.17 log units) between middle value and limit.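

In this assay, only compound 2 of the three gives a number, while compound 3 stays at a limit of the assay, like compound 1. Hydrogen in place of chloro on an aromatic carbon gives an at least 1.9-fold higher number from compound 2 to compound 3 (0.29 log units; that floor lies within the scatter), so any effect of the chloro cannot yet be told from scatter. The step from compound 1 to compound 3 cannot be read, and the true size of the other step stays hidden: the limit of > 30000 nM in this assay, at which 2 of the 3 values shown sit.

From the compounds shown here alone, whether a phenyl group carrying an amine or a carboxylic acid on this nitrogen would give a clearly lower number stays open.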